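Swapping the Amine Linker for an Ether Bridge

The compounds below may be only part of what the source reports. "The series", "measured", "known", "first", "only" and "open" are said of these compounds alone.

Compound 1 `CC(C)c1onc(-c2c(Cl)cccc2Cl)c1COc1ccc(N(C)Cc2cccc(C(=O)O)c2)c(C(F)(F)F)n1` gives 80 nM in a functional assay on HEK293 cells for agonist activity at Bile acid receptor (Homo sapiens); a higher number here means that more compound is needed for the effect, a lower number that less compound is needed.
Compound 2 `CN(Cc1cccc(C(=O)O)c1)c1ccc(OCc2c(-c3c(Cl)cccc3Cl)noc2C2CC2)nc1C(F)(F)F` gives 9 nM in this assay.
Compound 3 `CC(C)c1onc(-c2c(Cl)cccc2Cl)c1COc1ccc(N(C)Cc2cccc(C(=O)NS(C)(=O)=O)c2)c(C(F)(F)F)n1` gives 279 nM in this assay.

Among these three, compound 2 has the lowest number in this assay; its nearest neighbour is compound 1, and compound 3 lies furthest from it, both gaps being beyond the scatter.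

Compound 4 `O=C(O)c1cccc(OCc2ccc(OCc3c(-c4c(Cl)cccc4Cl)noc3C3CC3)nc2C(F)(F)F)c1` differs from compound 2 in a single place: (3-carboxyphenoxy)methyl in place of (3-carboxybenzyl)(methyl)amino on an aromatic carbon. Neither measured step touches this part of the molecule. The change an 8.9-fold lower number from compound 1 to compound 2 (0.95 log units; beyond the scatter) concerns the small ring at the far end of the shared core, and a 3.5-fold higher number from compound 1 to compound 3 (0.54 log units; beyond the scatter) concerns the acid itself; both are modest in size and leave the bridge untouched. For the measured compounds named here, the expectation for the new bridge therefore rests on no direct precedent, only on the observation that modest changes elsewhere gave modest steps.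

For compound 4 a somewhat higher number is expected, a step of a 3.3-fold higher number from compound 2 to compound 4 (0.52 log units; beyond the scatter), that is 30 nM with a range of 6 nM to 150 nM.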

Compound 4, half-maximal effective concentration: 151 nM
Estimate against measurement, compound 4: 5.0-fold (0.70 log units) below; the measured number lies above the stated range.
By their numbers in this assay, from the lowest: compound 2; then compounds 1, 4 and 3 (each within the scatter of the next, the first and the last beyond it).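

The bridge that carries the carboxylic acid proves to be a sensitive part of the molecule: with the acid and the cyclopropyl group left in place, swapping (3-carboxybenzyl)(methyl)amino for (3-carboxyphenoxy)methyl gives a 17-fold higher number from compound 2 to compound 4 (1.22 log units; beyond the scatter), the largest step seen so far in this series. This loss comes even though the leaving and entering groups have the same counts of hydrogen-bond donors and acceptors and neither carries a net charge. Nothing available here explains the size of this step.

The swap removes the nitrogen and its methyl group and also introduces a new oxygen, so the compounds shown cannot tell which of these changes matters. As far as these compounds go, how a bridge built around a thioether or an amide would compare with these two remains open.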